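Swapping a Chain-End Hydroxy for a Piperidine Ring

The source may hold more compounds than are shown below. What is called first, only, known or untested is meant among the compounds shown, and "the series" means these compounds.

Of the compounds shown here, three have been measured in an assay on HEK293 cells for displacement of a labelled ligand from 5-hydroxytryptamine receptor 4 (Homo sapiens), read by scintillation counting; a lower number here means a stronger inhibitor, a higher number a weaker inhibitor. Compound 1 `CC(C)n1c(=O)n(C(=O)NC2CCNCC2)c2ccccc21` gives 1580 nM and compound 2 `COc1ccc2[nH]cc(C(=O)NC3CCNCC3)c2c1` gives 3160 nM. Compound 3 `COc1cc(N)c(Cl)cc1C(=O)NC1CCN(CCCCCO)CC1` gives 63.1 nM, the lowest of the three numbers; its nearest neighbour is compound 1, whose number is higher by a gap well beyond the scatter, and compound 2 lies further away still. On these numbers compound 3 is therefore the strongest inhibitor of the set.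

Compound 4 `COc1cc(N)c(Cl)cc1C(=O)NC1CCN(CCCCCN2CCCCC2)CC1` has not yet been measured in this assay. It differs from compound 3 in a single place: piperidin-1-yl in place of hydroxy on a saturated chain carbon, five bonds along the chain from an amine nitrogen in a ring. The change sits at the far end of the chain that hangs from the ring amine nitrogen, leaving the amide and the substituted benzene ring of the shared core untouched.

Going by the values given here, no pair of measured compounds shows this particular change, so there is no measured step to lean on; the expectation rests only on the value of compound 3 and the size of the alteration. The step from compound 3 to compound 4 is expected to be small, a 1.6-fold higher number from compound 3 to compound 4 (0.20 log units; within the scatter), and may fall within the scatter in either direction. For compound 4 a value of 100 nM is estimated, with a plausible range from 20 nM to 500 nM.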

Compound 4, inhibition constant: 10 nM
Compound 4: middle estimate off by 10-fold (1.00 log units), on the high side, outside the stated range (below it).
By their numbers in this assay, from the lowest: compound 4; then compound 3; then compounds 1 and 2 (each within the scatter of the next).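

In this assay, the far end of the chain on the ring amine nitrogen proves to be a place where a change registers: the step (a 6.3-fold lower number from compound 3 to compound 4 (0.80 log units; beyond the scatter)) lies beyond the scatter, so the group at this end affects the number. The hydroxy, with one heavy atom and one hydrogen-bond donor, gives way to piperidin-1-yl, with six heavy atoms, a six-membered non-aromatic ring and no hydrogen-bond donor, and the number falls rather than rises. This single pair therefore shows that a much bigger end group is tolerated here, while nothing at hand explains the gain or credits it to any one feature of the new group.

The compounds shown leave open whether the gain belongs to the ring or to its nitrogen, a question that an open-chain diethylamino group or a cyclohexyl ring at the same place could help to separate. They also leave open how much the distance matters, which a shorter or longer chain carrying the same piperidin-1-yl group would begin to answer.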